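Benzyloxy to isobutoxy on a shared core

This account rests on a few compounds, and the source may have more. Where it says the series, first, only, none or still open, it means among the compounds named here.

Compound 1 `c1ccc(COc2cc(-c3ccccc3)nc3ccccc23)cc1`: > 10 ug/mL (a limit)
Compound 2 `Oc1cc(-c2ccccc2)nc2ccc(Cl)cc12`: 0.5 ug/mL

In a functional assay on L1210 (1565) cells (Mus musculus) for cytotoxicity (a higher number here means that more compound is needed for the effect, a lower number that less compound is needed), compound 1 gives > 10 ug/mL. On these data alone, that reading is a limit of the assay and not a number, so the true position of compound 1 remains open. By contrast, compound 2 gives a true number, 0.5 ug/mL.

The next compound to be tested is compound 3 `CC(C)COc1cc(-c2ccccc2)nc2ccccc12`, which keeps the core of compound 1 and changes only the group on the oxygen. The change is isopropyl in place of phenyl on a saturated chain carbon bound to an oxygen on an aromatic ring. In words, isopropyl stands in place of phenyl on a saturated chain carbon bound to an oxygen on an aromatic ring, turning benzyloxy into isobutoxy.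

Among the compounds with values here, no measured step shows what this swap does, so compound 1, at > 10 ug/mL, is the only guide. No change beyond the usual scatter is expected, in either direction, and another limit reading would be no surprise. The expected shift is a step that the limit leaves unreadable from compound 1 to compound 3. Compound 3 is estimated at 12 ug/mL, with an expected range of 3 ug/mL to 40 ug/mL.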

Compound 3, half-maximal effective concentration: > 10 ug/mL
Compound 3: only a limit was reported; the forecaster's own chance of this, stated with the estimate: 65%; the middle value is on the limit's open side.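

In this assay compound 3 gives > 10 ug/mL as a limit of the assay. No step can be read between compound 1 and compound 3, because both rest on the same limit: the limit of > 10 ug/mL in this assay, at which 2 of the 3 values shown sit.

The compounds shown leave open where compound 1 and compound 3 truly stand, and so whether isopropyl in place of phenyl changes the effect at all.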